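The compounds below may be only part of what the source reports. "The series", "measured", "known", "first", "only" and "open" are said of these compounds alone.

Compound 1 `CCC(C)COc1cccc2ccc(N)nc12`, in an assay on cells with melanin-concentrating hormone receptor 1 (Homo sapiens) as the target, read by radioligand binding (on this read-out higher numbers stand for weaker inhibition and lower numbers for stronger inhibition), compound 1 gives 36 nM.
Compound 2 `CC(C)=CCOc1cccc2ccc(N)nc12`; for compound 2 the result is only a limit, > 2000 nM.
Compound 3 `COC(C)(C)CCOc1cccc2ccc(N)nc12`, compound 3 gives 132 nM.

Compound 3 holds the highest of the two numbers, with compound 1 nearest at a 3.7-fold higher number from compound 1 to compound 3 (0.56 log units; beyond the scatter); from compound 2, the step is an at least 15-fold lower number from compound 2 to compound 3 (1.18 log units; beyond the scatter), anchored on (the limit of > 2000 nM in this assay, at which 1 of the 3 values shown sits).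

Compound 4 `Nc1ccc2cccc(OCC3CCC3)c2n1` differs from compound 3 as follows: cyclobutyl in place of 2-methoxy-2-methylpropyl on a saturated chain carbon bound to an oxygen on an aromatic ring. The entering cyclobutyl is a four-membered ring of carbon only, closer in kind to the sec-butyl of compound 1 than to the 2-methylprop-1-en-1-yl of compound 2. The step from compound 1 to compound 3 was modest, so a modest move back in the direction of compound 1 is expected in this assay, a 2.9-fold lower number from compound 3 to compound 4 (0.47 log units; beyond the scatter). Compound 4 is therefore estimated at 45 nM, range 15 nM to 140 nM.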

Compound 4, half-maximal inhibitory concentration: 432 nM
For compound 4 the middle estimate is 9.6-fold (0.98 log units) below the measured one; the whole stated range lies below it.
By their numbers in this assay, from the lowest: compound 1; then compound 3; then compound 4. At a limit, above all of these: compound 2.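

In this assay cyclobutyl does not stand in for sec-butyl on this saturated chain carbon, with a 12-fold higher number from compound 1 to compound 4 (1.08 log units; beyond the scatter) as the cost of the swap. Replacing 2-methoxy-2-methylpropyl with cyclobutyl gives no gain either, with a 3.3-fold higher number from compound 3 to compound 4 (0.51 log units; beyond the scatter), so carbon-only groups now fall on both sides of compound 3, and a carbon-only group alone does not set the order. Compound 2 remains a limit, and an at least 4.6-fold lower number from compound 2 to compound 4 (0.66 log units; beyond the scatter) counts only as a bound: the limit of > 2000 nM in this assay, at which 1 of the 4 values shown sits.

As far as these compounds go, whether a larger ring such as cyclopentyl, or a terminal amine on the chain, would return towards compound 1 stays open.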